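Compound 4: a new group on the amide-type nitrogen

The compounds below may be only part of what the source reports. "The series", "measured", "known", "first", "only" and "open" are said of these compounds alone.

In a functional assay on BT-483 cells (Homo sapiens) for cytotoxicity, read by MTT assay, with a stated time of 24 h (a lower number here means a stronger inhibitor, a higher number a weaker inhibitor), compound 1 `CCNc1cc(-c2ccc(NC(=O)Nc3ccc(C(F)(F)F)cc3)cc2C)ccn1` gives 19700 nM as its value, compound 2 `CCNc1cc(-c2ccc(NC(=O)Nc3ccc(C(F)(F)F)cc3)cc2C(F)(F)F)ccn1` gives 16400 nM and compound 3 `CCNc1cc(-c2ccc(NC(=O)Nc3cccc(Cl)c3)cc2F)ccn1` gives 18500 nM in the same test. Compound 3 therefore stands level with the other two, as all three lie within the usual scatter of one another. Compound 4 `CCNc1cc(-c2ccc(NC(=O)Nc3ccc(C(F)(F)F)cc3)cc2F)ccn1` differs from compound 3 by having 4-(trifluoromethyl)phenyl in place of 3-chlorophenyl on an amide-type nitrogen. For the measured compounds named here, no measured step covers this exact swap. Going by the values given here, the only measured step is a 1.2-fold lower number from compound 1 to compound 2 (0.08 log units; within the scatter) for trifluoromethyl in place of methyl on an aromatic carbon, a different change that stays within the scatter. Compound 1 and compound 2 already carry the entering 4-(trifluoromethyl)phenyl, yet neither value separates from that of compound 3, which has 3-chlorophenyl. The estimated step is a 1.1-fold lower number from compound 3 to compound 4 (0.04 log units; within the scatter) in this assay, so no change beyond the scatter is expected. For compound 4 the expected value is 17000 nM with an estimated range of 9000 nM to 30000 nM around it.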

Compound 4, half-maximal inhibitory concentration: 26800 nM
For compound 4 the middle estimate is 1.6-fold (0.20 log units) below the measured one, within the range that was stated.
By their numbers in this assay, from the lowest: compounds 2, 3, 1 and 4 (each within the scatter of the next).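

In this assay, for the compounds shown here, 4-(trifluoromethyl)phenyl in place of 3-chlorophenyl on the amide-type nitrogen gives a 1.4-fold higher number from compound 3 to compound 4 (0.16 log units; within the scatter), the only measured step at this position, and it does not separate the two groups. The aromatic carbon that carries fluoro in compound 4 gives the same picture, with a 1.6-fold higher number from compound 2 to compound 4 (0.21 log units; within the scatter) for fluoro in place of trifluoromethyl and a 1.4-fold higher number from compound 1 to compound 4 (0.13 log units; within the scatter) for fluoro in place of methyl, so fluoro, methyl and trifluoromethyl are not told apart there. No measurement at hand accounts for how closely these values sit.

Going by these compounds alone, only two substituted phenyl groups appear on the amide-type nitrogen, so it remains open whether this position can shift the number at all. A different group there, such as a pyridine ring, a carboxylic acid or a longer alkyl chain, might still give a value that stands apart from these.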